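This account rests on a few compounds, and the source may have more. Where it says the series, first, only, none or still open, it means among the compounds named here.

The measured compounds:
compound 1, `COc1ccc(CO/N=C/c2c(-c3ccc4ccccc4c3)nc3occn23)cc1`, gives 4400 nM in an assay on HepG2 cells for agonist activity at nuclear receptor subfamily 1 group I member 3 (Homo sapiens), read by a luciferase reporter, with a stated time of 23 h; on this read-out lower numbers stand for an effect already at smaller amounts and higher numbers for an effect only at larger amounts of compound;
compound 2, `CC(C)(C)c1ccc(CO/N=C/c2c(-c3ccc4ccccc4c3)nc3occn23)cc1`, gives 7900 nM in this assay;
compound 3, `C(=N/OCc1ccc(Oc2ccccc2)cc1)\c1c(-c2ccc3ccccc3c2)nc2occn12`, is reported in this assay as "not active" (no number reported), with no number.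

Compound 3 therefore stands apart from compounds 1 and 2: the two of them carry numbers, and the step of a 1.8-fold higher number from compound 1 to compound 2 (0.25 log units; within the scatter) shows that exchanging one group para to the large group on that ring left the read-out within the scatter, while compound 3 gave no measurable effect at all.

Compound 4, `Clc1ccc(CO/N=C/c2c(-c3ccc4ccccc4c3)nc3occn23)cc1`, is reached from compound 3 by chloro in place of phenoxy on an aromatic carbon. Within the data shown here, no measured step covers this exchange directly. Among the measured compounds shown here, the only step available, a 1.8-fold higher number from compound 1 to compound 2 (0.25 log units; within the scatter), concerns the same position and was within the scatter, so it gives no direction for chloro. For the measured compounds named here, since compound 3 has no number, no step from compound 3 to compound 4 can be computed; the estimate stands alone.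

Compound 4 is expected to behave like compounds 1 and 2 rather than compound 3, with an estimated 5000 nM, in a range from 1500 nM to 20000 nM.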

Compound 4, half-maximal effective concentration: 990 nM
Estimate against measurement, compound 4: 5.1-fold (0.70 log units) above; measured number outside the range, below it.
By their numbers in this assay, from the lowest: compound 4; then compounds 1 and 2 (each within the scatter of the next).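

In this assay this place on the ring proved responsive after all: chloro gave an 8.0-fold lower number from compound 2 to compound 4 (0.90 log units; beyond the scatter) and a 4.4-fold lower number from compound 1 to compound 4 (0.65 log units; beyond the scatter), both beyond the scatter, whereas the exchange of methoxy for tert-butyl had not moved the read-out beyond it. Among these compounds, compound 4 thus has the lowest number of the three measured compounds, while no step from compound 3 can be read, as that compound has no number. Nothing available explains why chloro differs from the other groups at this place.

The compounds shown leave open whether bromo, fluoro, an amine or a carboxylic acid at this place would match or pass chloro. They also leave open whether chloro would give a similar result on another carbon of the same ring.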